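From azido to (allyloxycarbonyl)amino: what compound 4 may show

This account rests on a few compounds, and the source may have more. Where it says the series, first, only, none or still open, it means among the compounds named here.

Compound 1 `C=C(C)[C@@H]1CC=C(CN(OC)C2OC[C@@H](O)[C@H](O)[C@H]2O)CC1`: 202000 nM
Compound 2 `C=C(C)[C@@H]1CC=C(CN(OC)C2O[C@H](CO)[C@@H](O)[C@H](O)[C@H]2N=[N+]=[N-])CC1`: 221000 nM
Compound 3 `C=C(C)[C@@H]1CC=C(CN(OC)C2O[C@H](CN=[N+]=[N-])[C@@H](O)[C@H](O)[C@H]2O)CC1`: 163000 nM

All three values come from a functional assay on A549 cells (Homo sapiens) for cytotoxicity, read by resazurin assay, with a stated time of 48 h (on this read-out lower numbers stand for stronger inhibition and higher numbers for weaker inhibition), and lie within the usual scatter of one another. Compound 2 therefore stands level with compound 1 and compound 3, and no order can be read among them.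

The step under consideration leads to compound 4 `C=CCOC(=O)N[C@H]1C(N(CC2=CC[C@@H](C(=C)C)CC2)OC)O[C@H](CO)[C@@H](O)[C@@H]1O`, with (allyloxycarbonyl)amino in place of azido on a saturated ring carbon.

Going by the values given here, no measured step touches this exchange directly. The only one available is a 1.2-fold lower number from compound 1 to compound 3 (0.09 log units; within the scatter), for azidomethyl in place of hydrogen on a saturated ring carbon, and it stays within the scatter. Among the compounds with values here, none of the measured compounds carries the entering group, so the range must stay wide.

Given that small step, no change beyond the scatter is expected in this assay, and the estimate is a 1.3-fold lower number from compound 2 to compound 4 (0.11 log units; within the scatter). Compound 4 is estimated at 170000 nM, with an expected range from 70000 nM to 320000 nM.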

Compound 4, half-maximal inhibitory concentration: 114000 nM
Compound 4: middle estimate off by 1.5-fold (0.17 log units), on the high side; the measured number falls inside the stated range.
By their numbers in this assay, from the lowest: compounds 4, 3, 1 and 2 (each within the scatter of the next).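

At this saturated ring carbon, the exchange of azido for (allyloxycarbonyl)amino gives a 1.9-fold lower number from compound 2 to compound 4 (0.29 log units; within the scatter) in this assay, so the change stays small by that read-out. The earlier compounds shown here carried only azido at this position, whereas compound 4 shows that a group of 7 heavy atoms, with a hydrogen-bond donor and a carbonyl, can enter there without a change beyond the scatter. Nothing in hand explains why the number holds so close to that of compound 2. The compounds shown leave open whether a free amine or a short acetylamino group on the same ring carbon would behave the same way. They also leave open whether a longer carbamate chain or a carboxylic acid there would carry the number beyond the scatter.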